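The compounds below may be only part of what the source reports. "The series", "measured", "known", "first", "only" and "open" are said of these compounds alone.

In a functional assay on the whole organism with Mus musculus as the target, at a dose of 100 mg/kg by the intraperitoneal route (a higher number here means more inhibition at the dose given (going by the name of the read-out), a lower number less inhibition), compound 1, with the structure `CN(C)C(=O)/C=C1\CCc2ccc(F)cc21`, gives 100%. Compound 2, `CCN(C)C(=O)/C=C1\CCc2c(F)cc(F)cc21`, gives 100% in this assay, a result level with compound 1 at the digits reported, so that the two show no difference beyond the scatter. The step followed here goes from compound 2 to compound 3, `CN(C)C(=O)/C=C1\CCc2c(F)cc(F)cc21`, which has not yet been tested in this assay. The change is hydrogen in place of methyl on a saturated chain carbon bound to an amide-type nitrogen; cut one bond further out it reads ethyl to methyl, or ethyl(methyl)carbamoyl to dimethylcarbamoyl. Compound 3 thus carries the dimethylcarbamoyl group that compound 1 carries, while otherwise matching compound 2. Because compound 1 gives 100% and compound 2 gives 100% in this assay, no step beyond the scatter is expected in that read-out when the ethyl(methyl)amino group becomes dimethylamino. The step this expectation means, a number 3 percentage points lower from compound 2 to compound 3 (within the scatter), is estimated to stay within the scatter. Compound 3 is therefore expected to give 97%, within a range from 80% to 100%.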

Compound 3, a percentage reported as inhibition, in the whole organism at one dose (the size of the read-out at that dose, not a potency): 100%
Compound 3: middle estimate off by 3 percentage points, on the low side, within the range that was stated.
By their numbers in this assay, from the lowest: compounds 1, 2 and 3 (each within the scatter of the next).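

In this assay, hydrogen in place of methyl on a saturated chain carbon bound to an amide-type nitrogen can now be read on its own, as the change from ethyl(methyl)carbamoyl to dimethylcarbamoyl gives no change at the digits printed from compound 2 to compound 3 (within the scatter) on an otherwise unchanged structure. Compounds 1 and 2 differ in more than one place, so they could not separate this change from the fluoro group, whereas compound 3 also isolates fluoro in place of hydrogen on an aromatic carbon, which gives no change at the digits printed from compound 1 to compound 3 (within the scatter) in the same read-out. Nothing measured here explains why either change leaves the read-out as it stands.

All three compounds print the same value at a single dose, so the result does not tell whether they would separate at a lower dose or whether either change affects potency. It also leaves open how a longer chain such as propyl, a cyclic amine such as pyrrolidine or morpholine in place of the dimethylamino group, or a carboxylic acid in place of the dimethylcarbamoyl group would read in this whole-organism test.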